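The compounds below may be only part of what the source reports. "The series", "measured", "known", "first", "only" and "open" are said of these compounds alone.

The measured compounds:
Compound 1, `CSc1ccnc(CSc2nc3cc(OC(C)C)ccc3[nH]2)c1`: in an assay on isolated protein for inhibition of receptor-type tyrosine-protein phosphatase C (Homo sapiens) (on this read-out higher numbers stand for weaker inhibition and lower numbers for stronger inhibition), compound 1 gives > 1000000 nM, which is a limit of the assay rather than a number.
Compound 2, `CSc1ccnc(C[S+]([O-])c2nc3cc(OC4CCCCC4)ccc3[nH]2)c1`: in this assay compound 2 gives 80500 nM.
Compound 3, `Cc1ccnc(C[S+]([O-])c2nc3cc(OC(C)C)ccc3[nH]2)c1`: in this assay compound 3 gives 380000 nM.

Of the two compounds with a number, compound 3 has the higher one, which here means the weaker inhibition; its nearest neighbour is compound 2, and the gap between the two lies beyond the usual scatter. Compound 1 sits at the limit of > 1000000 nM in this assay, at which 1 of the 3 values shown sits, so it can only be placed at the edge of what the assay reports.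

Compound 4, `CC(C)Oc1ccc2[nH]c([S+]([O-])Cc3ccccn3)nc2c1`, has not been measured in this assay. It differs from compound 3 in one place: hydrogen in place of methyl on an aromatic carbon, in words hydrogen in place of methyl on an aromatic carbon, so that 4-methylpyridin-2-yl becomes pyridin-2-yl. Going by the values given here, no pair of measured compounds differs in just this way, so there is no measured step to lean on. Removing a single carbon is a small change, and the expected step of a 1.3-fold higher number from compound 3 to compound 4 (0.12 log units; within the scatter) is one that stays within the scatter, if anything toward a higher number. Compound 4 is therefore estimated at 500000 nM in this assay, with an expected range from 150000 nM to 1500000 nM.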

Compound 4, half-maximal inhibitory concentration: 120000 nM
Estimate against measurement, compound 4: 4.2-fold (0.62 log units) above; the whole stated range lies above it.
By their numbers in this assay, from the lowest: compounds 2 and 4 (each within the scatter of the next); then compound 3. At a limit, above all of these: compound 1.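

In this assay, going by these compounds alone, this is the first step in which only one place changes, and it gives the position on the pyridine ring a measured direction: going from 4-methylpyridin-2-yl to pyridin-2-yl brings a 3.2-fold lower number from compound 3 to compound 4 (0.50 log units; beyond the scatter). The step is modest but lies beyond the scatter, so in this pair the methyl is not needed for the inhibition seen, and the compound with hydrogen in its place is the stronger inhibitor. This rests on a single pair of compounds, and nothing in the data at hand accounts for why removing this one carbon moves the number in this direction.

From the compounds shown here alone, it remains open whether an amine, a methoxy group or a carboxylic acid in the same place would push the number further down or back up, since the only substituents seen on this ring are methyl, hydrogen and the methylthio group of compounds 1 and 2, and those two compounds differ from compound 4 in more than one place. Going by these compounds, it is also open whether the same change would give a similar step on a compound carrying the cyclohexyloxy group of compound 2, which is the other ether seen on the shared core.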